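The compounds below may be only part of what the source reports. "The series", "measured", "known", "first", "only" and "open" are said of these compounds alone.

Compound 2 `CCOC(=O)C1=C(N/C=N/c2ccc([N+](=O)[O-])cc2)Nc2[nH]nc(C)c2C1c1ccc(N(C)C)cc1` belongs to a small series built on a shared core, tested in a functional assay on HepG2 cells (Homo sapiens) for inhibition, read by MTT assay, with a stated time of 48 h; a higher number here means a weaker inhibitor, a lower number a stronger inhibitor. In this assay compound 2 gives 50900 nM. Its only measured relative, compound 1 `CCOC(=O)C1=C(N/N=C(\C#N)C(N)=O)Nc2[nH]nc(C)c2C1c1ccc(N(C)C)cc1`, gives 48400 nM in this assay, and the two numbers sit within the scatter of each other: the step of a 1.1-fold higher number from compound 1 to compound 2 (0.02 log units; within the scatter) shows that exchanging one substituent for the other on the amine nitrogen left the result unchanged.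

Compound 3 `CCOC(=O)C1=C(N)Nc2[nH]nc(C)c2C1c1ccc(N(C)C)cc1` has not yet been measured. It differs from compound 2 by a hydrogen atom in place of a group of 11 heavy atoms (7 carbon, 2 nitrogen, 2 oxygen; one six-membered aromatic ring of carbon only), on an amine nitrogen. Going by the values given here, the single known step involved swapping two substituents at that position, not removing one, so it offers no direct guide; it shows only that the read-out tolerated a change there. Compound 3 is therefore expected to give about 60000 nM in this assay, somewhere between 20000 nM and 180000 nM. That estimate implies a step of a 1.2-fold higher number from compound 2 to compound 3 (0.07 log units; within the scatter), no larger than the scatter.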

Compound 3, half-maximal inhibitory concentration: 4240 nM
Estimate against measurement, compound 3: 14-fold (1.15 log units) above; the measured number lies below the stated range.
By their numbers in this assay, from the lowest: compound 3; then compounds 1 and 2 (each within the scatter of the next).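

Removing the substituent from the amine nitrogen, rather than exchanging it for another, is what moves the number in this assay: a hydrogen atom in place of the group of 11 heavy atoms gives a 12-fold lower number from compound 2 to compound 3 (1.08 log units; beyond the scatter), and a hydrogen atom in place of the group of 7 heavy atoms gives an 11-fold lower number from compound 1 to compound 3 (1.06 log units; beyond the scatter). Both steps run in the same direction even though only the larger group carries a ring, so compound 3, with its unsubstituted amine, is the strongest inhibitor of the three. The earlier pair showed only that one substituent could stand in for the other, not that both lie far on the weak side of the unsubstituted compound. No measurement shown here explains this difference.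

The compounds shown go from hydrogen straight to groups of 7 and 11 heavy atoms, so it remains open whether a methyl or an acetyl group on this nitrogen would keep the number of compound 3.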